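This account rests on a few compounds, and the source may have more. Where it says the series, first, only, none or still open, it means among the compounds named here.

Measured compounds:
compound 1 `COc1ccc(C(=O)OC2(C(=O)Nc3ccc([N+](=O)[O-])cc3)CCCCC2)cc1` gives 57.1 nM
compound 2 `O=C(/C=C/c1ccccc1)OC1(C(=O)Nc2ccc([N+](=O)[O-])cc2)CCCCC1` gives 52.9 nM
compound 3 `CC(=O)OC1(C(=O)Nc2ccc([N+](=O)[O-])cc2)CCCCC1` gives 519 nM

All three numbers come from a functional assay on HepG2 cells (Homo sapiens) for inhibition, read by MTT assay, with a stated time of 72 h; a higher number here means a weaker inhibitor, a lower number a stronger inhibitor. Compound 1 stands second highest of the three: its nearest neighbour is compound 2, and the step of a 1.1-fold lower number from compound 1 to compound 2 (0.03 log units; within the scatter) stays within the scatter; its furthest is compound 3, reached through the step of a 9.1-fold higher number from compound 1 to compound 3 (0.96 log units; beyond the scatter). Compound 2 shows the same picture against compound 3, with the step of a 9.8-fold higher number from compound 2 to compound 3 (0.99 log units; beyond the scatter).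

The unmeasured compound 4 `CC(=O)Oc1ccccc1C(=O)OC1(C(=O)Nc2ccc([N+](=O)[O-])cc2)CCCCC1` departs from compound 1 in a single place: 2-acetoxyphenyl in place of 4-methoxyphenyl on a carbonyl carbon. Two kinds of step bear on this change. The steps from compound 1 or compound 2 to compound 3 show that cutting the group on this carbonyl carbon back to methyl costs a modest but clear amount. The step from compound 1 to compound 2 shows that swapping one aromatic group for another unsaturated one of similar size leaves the number where it was. Compound 4 keeps a six-membered aromatic ring at the same place, so the expected step in this assay is a 1.2-fold higher number from compound 1 to compound 4 (0.09 log units; within the scatter), that is, none beyond the scatter in either direction. Compound 4 is therefore estimated at 70 nM, with a range from 25 nM to 200 nM.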

Compound 4, half-maximal inhibitory concentration: 17.7 nM
For compound 4 the middle estimate is 4.0-fold (0.60 log units) above the measured one; the measured number lies below the stated range.
By their numbers in this assay, from the lowest: compound 4; then compounds 2 and 1 (each within the scatter of the next); then compound 3.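

In this assay the group on this carbonyl carbon proved able to do more than hold the number level: the step of a 3.2-fold lower number from compound 1 to compound 4 (0.51 log units; beyond the scatter) lies beyond the scatter, and so does the step of a 3.0-fold lower number from compound 2 to compound 4 (0.48 log units; beyond the scatter) in the same direction, whereas the earlier exchange of 4-methoxyphenyl for 2-phenylethenyl had changed nothing beyond the scatter. Having an unsaturated group of about this size at the position is therefore not the whole story, since 2-acetoxyphenyl keeps the same six-membered aromatic ring of carbon only as 4-methoxyphenyl and still separates from it. For the compounds shown here, the range reachable at this position also widens, with the step of a 29-fold lower number from compound 3 to compound 4 (1.47 log units; beyond the scatter) being large where the earlier steps from the methyl compound were modest. Nothing measured here explains why 2-acetoxyphenyl behaves differently from the other groups.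

What a hydroxyl group in place of the acetoxy part of 2-acetoxyphenyl would give remains open, so the compounds shown cannot separate the contribution of the acetoxy part from that of the ring. As far as these compounds go, the effect of an amine or a carboxylic acid on the same ring also remains open.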